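Series notes: side-chain change from compound 2 to compound 3

The source may hold more compounds than are shown below. What is called first, only, known or untested is meant among the compounds shown, and "the series" means these compounds.

In a functional assay on the whole organism (Tail, strain ICR) with Mus musculus as the target, in the tail flick test, with a stated time of 60 min, at a dose of 6.25 umol/kg by the oral route (on this read-out lower numbers stand for a weaker effect and higher numbers for a stronger effect at the one dose given), compound 2 `NCCCC[C@H](NC(=O)CN(c1nc(Cl)nc2[nH]cnc12)C1CC1)C(=O)O` gives 16.6%. Of the two numbers recorded it sits at the lower one, with compound 1 `N=C(N)NCCC[C@H](NC(=O)CN(c1nc(Cl)nc2[nH]cnc12)C1CC1)C(=O)O` nearest at 17.5%, the gap a number 0.9 percentage points lower from compound 1 to compound 2 (within the scatter) lying within the scatter. Compound 3 `CC(C)C[C@H](NC(=O)CN(c1nc(Cl)nc2[nH]cnc12)C1CC1)C(=O)O` is the next to be measured. The difference is isopropyl in place of 3-aminopropyl on a saturated chain carbon, two bonds along the chain from an amide-type nitrogen and a carbonyl carbon. Within the data shown here, the one measured step that bears on this region of the molecule is a number 0.9 percentage points lower from compound 1 to compound 2 (within the scatter), which exchanged one group for another on the same side chain and did not move the read-out beyond the scatter. That step exchanged one group for another, whereas here the 3-aminopropyl group is removed in favour of isopropyl, so it is a weak guide. No step beyond the scatter is expected for a number 2.6 percentage points lower from compound 2 to compound 3 (within the scatter). Compound 3 is therefore estimated at 14%, in a range from 4% to 27%.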

Compound 3, a percentage reported as activity, at one dose (the size of the read-out at that dose, not a potency): 10.7%
Beside the measured number, compound 3's estimate is 3.3 percentage points above it; the measured number falls inside the stated range.
By their numbers in this assay, from the lowest: compounds 3, 2 and 1 (each within the scatter of the next).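

In this assay, exchanging 3-aminopropyl, with its hydrogen-bond donor and acceptor, for isopropyl, with neither, gives a number 5.9 percentage points lower from compound 2 to compound 3 (within the scatter), so at this position a side chain without nitrogen stays within the scatter of one that carries it. The wider exchange of the 6-heavy-atom group of compound 1 for the 3-heavy-atom group gives a number 6.8 percentage points lower from compound 1 to compound 3 (within the scatter), so the three side chains shown, basic nitrogen groups and branched hydrocarbon alike in name, cannot be separated by this read-out at this single dose. Nothing available explains these numbers or ties them to any property of the groups. From the compounds shown here alone, whether a carboxylic acid, a phenyl ring or a longer alkyl chain at this position would give a step beyond the scatter stays open. Also open, going by these compounds, is whether the same closeness would hold at another dose or time.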